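Sulfur and selenium analogues in a cell-kill screen

A few compounds are considered here, and "the series" means these few. Any claim that something is new, unique, unknown or untested is made for them only; others in the source may bear on it.

Compound 1, `C[Se]c1nc(N)c2ccccc2n1` — in a functional assay on CCRF-CEM cells (Homo sapiens) for cytotoxicity, read by MTT assay, with a stated time of 72 h (on this read-out higher numbers stand for lower toxicity in this test and lower numbers for higher toxicity in this test), compound 1 gives > 100000 nM, which is a limit of the assay rather than a number.
Compound 2, `COc1ccc(CNc2nc(SC)nc3ncccc23)cc1` — in this assay compound 2 gives > 100000 nM, again a limit and not a number.
Compound 3, `CSc1ccc(CNc2nc([SeH])nc3ccccc23)cc1` — in this assay compound 3 gives > 100000 nM, likewise a limit only.

Compound 2 therefore has no numerical standing among the results shown: there are no numbers, only limits, and all three compounds sit at the same place, as the limit of > 100000 nM in this assay, at which 3 of the 3 values shown sit, records. Going by the values given here, no two measured compounds differ in a single place, so no measured step is available for comparison, and nothing is known about which structural feature, if any, moves the read-out.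

Compound 4, `CSc1nc(NCc2ccccc2)c2cccnc2n1`, is the next compound to be measured. It differs from compound 2 by hydrogen in place of methoxy on an aromatic carbon. With compound 2 at the limit and no measured step to draw on, the size of step in this assay that this change brings cannot be read from anything shown; the expectation is none beyond the scatter, with compound 4 most likely reported as a limit as well. For compound 4 the estimate in this assay is 100000 nM, with a range of 30000 nM to 300000 nM. The step this estimate means, a number no higher from compound 2 to compound 4 (the limit leaves the size open), is expected to be flat.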

Compound 4, concentration lethal to 50% of the cells: > 100000 nM
Compound 4: only a limit was reported (the forecaster's own chance of this, stated with the estimate: 80%); the middle value lies on the limit itself.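

Compound 2 and compound 4 both stand only as limits, so the change to hydrogen in place of methoxy on an aromatic carbon gives no readable step in this assay. The compounds shown leave open whether any structural change moves the read-out, and how toxic any of them is, since all share one result: the limit of > 100000 nM in this assay, at which 4 of the 4 values shown sit.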